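A few compounds are considered here, and "the series" means these few. Any claim that something is new, unique, unknown or untested is made for them only; others in the source may bear on it.

Measured compounds:
compound 1, `COc1ccc(-c2cc3ccccc3c(-c3ccc(O)cc3)n2)cc1`: > 50000 nM
compound 2, `COc1ccc(-c2cc3ccccc3c(-c3ccc(OC)cc3)n2)cc1`: > 50000 nM
compound 3, `COc1ccc(-c2cc3cc(C)ccc3c(-c3cccc(O)c3)n2)cc1OC`: 6510 nM

In a functional assay on DU-145 cells (Homo sapiens) for cytotoxicity, read by CCK-8 assay and cell counting, with a stated time of 72 h (a lower number here means a stronger inhibitor, a higher number a weaker inhibitor), compound 1 gives > 50000 nM, which is a limit of the assay and not a number. In this assay compound 2 likewise gives > 50000 nM, again a limit. The change from compound 1 to compound 2 is methyl in place of hydrogen on an oxygen on an aromatic ring, and the step that the two limits leave unreadable from compound 1 to compound 2 cannot be read because of the limit of > 50000 nM in this assay, at which 2 of the 3 values shown sit. Compound 3 is the only one of the three with a number; in this assay compound 3 gives 6510 nM. The difference between the core of compound 1 and that of compound 3 is not broken down here.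

Compound 4, `COc1cccc(-c2nc(-c3ccc(OC)c(OC)c3)cc3cc(C)ccc23)c1`, is not yet measured. It differs from compound 3 by methyl in place of hydrogen on an oxygen on an aromatic ring, the same change as that from compound 1 to compound 2, made at a place whose surroundings read the same. That earlier step gives no readable size, so the expectation rests on the position of compound 3 alone. The step of a 1.5-fold higher number from compound 3 to compound 4 (0.19 log units; within the scatter) is expected to be small, with much uncertainty. In this assay compound 4 is estimated at 10000 nM, between 3000 nM and 40000 nM.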

Compound 4, half-maximal inhibitory concentration: > 50000 nM
Compound 4 was reported as a limit; the forecaster's own chance of this, stated with the estimate: 25%; middle value at least 5.0-fold (0.69 log units) from the limit.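

In this assay, as far as these compounds go, the change from 3-hydroxyphenyl to 3-methoxyphenyl reads as an at least 7.6-fold higher number from compound 3 to compound 4 (0.88 log units; beyond the scatter), a step with a limit at its upper end, so its full size is unknown. The same methyl-for-hydrogen change on the core of compound 1 cannot be read, since both of its values are limits, and that leaves nothing to compare this step with: the limit of > 50000 nM in this assay, at which 3 of the 4 values shown sit. The result therefore shows a clear loss on one core, but it does not show whether the change carries the same effect from one core to another.

The compounds shown leave open what other groups in place of the hydroxy, such as an amine or a carboxylic acid, would do on the core of compound 3. They also leave open how a longer chain on that oxygen would read.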